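Shifting the fluorine on the fluorophenyl group

This account rests on a few compounds, and the source may have more. Where it says the series, first, only, none or still open, it means among the compounds named here.

For the measured compounds named here, compound 2 `O=C(CSc1nnc(-c2ccncc2)n1-c1ccccc1)N/N=C/c1ccccc1F` is one of two compounds so far measured in a functional assay on HepG2 cells (Homo sapiens) for inhibition, read by MTT assay, with a stated time of 48 h (a lower number here means a stronger inhibitor, a higher number a weaker inhibitor), and compound 2 gives 15200 nM. Going by the values given here, the only comparator is compound 1 `O=C(CSc1nnc(-c2ccncc2)n1-c1ccccc1)N/N=C/c1ccccc1`, which in this assay gives 18600 nM. The two differ by a single fluoro in place of hydrogen on an aromatic carbon, and the step of a 1.2-fold lower number from compound 1 to compound 2 (0.09 log units; within the scatter) is the whole of the measured evidence on this part of the series; compound 2 and compound 1 cannot be told apart by this assay.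

Compound 3 `O=C(CSc1nnc(-c2ccncc2)n1-c1ccccc1)N/N=C/c1cccc(F)c1` keeps every atom of compound 2 and changes only how they are joined: 3-fluorophenyl in place of 2-fluorophenyl on a carbon with a double bond to nitrogen. Among the compounds with values here, no measured step describes moving a fluorine from one ring carbon to another; the single available step concerned adding the fluorine and fell within the scatter. On that basis the step of a 1.0-fold lower number from compound 2 to compound 3 (0.01 log units; within the scatter) is expected to be small, with no direction that the data support. Compound 3 is estimated at 15000 nM in this assay, within a range of 7000 nM to 32000 nM.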

Compound 3, half-maximal inhibitory concentration: 24400 nM
For compound 3 the middle estimate is 1.6-fold (0.21 log units) below the measured one; low and high end bracket the measured number.
By their numbers in this assay, from the lowest: compounds 2, 1 and 3 (each within the scatter of the next).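

Swapping 2-fluorophenyl for 3-fluorophenyl on the carbon with a double bond to nitrogen gives the first measured step that moves a fluorine rather than adds one, and in this assay it is a 1.6-fold higher number from compound 2 to compound 3 (0.21 log units; within the scatter). Fluoro in place of hydrogen now has a second reading, a 1.3-fold higher number from compound 1 to compound 3 (0.12 log units; within the scatter), so neither fluorophenyl group can be separated from the unfluorinated phenyl group, and the two fluorophenyl groups cannot be separated from each other. No measured evidence accounts for these small differences.

The compounds shown carry only hydrogen or a single fluorine on this ring, so it remains open whether a different group there, such as a methoxy group, an amine or a carboxylic acid, would give a step beyond the scatter. Also open, on these data alone, is whether a change elsewhere on the shared core would separate compounds that the fluorine changes leave indistinguishable.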